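The compounds below may be only part of what the source reports. "The series", "measured", "known", "first", "only" and "open" are said of these compounds alone.

Within the data shown here, compound 3 `O=C1Nc2ccc(F)cc2/C1=N/NC(=S)N1CCN(c2ccccc2)CC1` carries a fluoro group on the shared core, and in a functional assay on MCF7 cells (Homo sapiens) for inhibition, read by MTT assay, with a stated time of 72 h (a lower number here means a stronger inhibitor, a higher number a weaker inhibitor), compound 3 gives 24300 nM, the second highest of the three numbers known so far. In this assay compound 1 `O=C1Nc2ccccc2/C1=N/NC(=S)N1CCN(c2ccccc2)CC1` gives 24900 nM, and compound 2 `COc1ccc2c(c1)/C(=N/NC(=S)N1CCN(c3ccccc3)CC1)C(=O)N2` gives 14400 nM. The steps of a 1.0-fold lower number from compound 1 to compound 3 (0.01 log units; within the scatter) and a 1.7-fold higher number from compound 2 to compound 3 (0.23 log units; within the scatter) both concern an exchange at this same aromatic carbon, and neither moved the number beyond the scatter. Compound 4 `O=C1Nc2ccc([N+](=O)[O-])cc2/C1=N/NC(=S)N1CCN(c2ccccc2)CC1` differs from compound 3 by nitro in place of fluoro on an aromatic carbon. Because a 1.0-fold lower number from compound 1 to compound 3 (0.01 log units; within the scatter) and a 1.7-fold higher number from compound 2 to compound 3 (0.23 log units; within the scatter) stayed within the scatter, no step beyond the scatter is expected in this assay from this further exchange. Compound 4 is therefore expected to give about 24000 nM in this assay, within 10000 nM to 55000 nM, an expected step of a 1.0-fold lower number from compound 3 to compound 4 (0.01 log units; within the scatter).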

Compound 4, half-maximal inhibitory concentration: 23300 nM
Compound 4: the middle estimate sits 1.0-fold (0.01 log units) above what was measured; the range from low to high includes it.
By their numbers in this assay, from the lowest: compounds 2, 4, 3 and 1 (each within the scatter of the next).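

Nitro brings more heavy atoms and two hydrogen-bond acceptors to this aromatic carbon, yet in this assay every step to compound 4 stays within the scatter (a 1.0-fold lower number from compound 3 to compound 4 (0.02 log units; within the scatter); a 1.6-fold higher number from compound 2 to compound 4 (0.21 log units; within the scatter); a 1.1-fold lower number from compound 1 to compound 4 (0.03 log units; within the scatter)). Among these compounds, this position has now carried hydrogen, methoxy, fluoro and nitro with no step beyond the scatter, and the first group with hydrogen-bond acceptors counted under the exchange changes nothing that can be read.

Going by these compounds, whether an amine or a carboxylic acid here would behave the same remains open. No evidence is available that could explain this result.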